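This account rests on a few compounds, and the source may have more. Where it says the series, first, only, none or still open, it means among the compounds named here.

Measured so far:
- compound 1, `Nc1n[nH]c2cc(-c3ccccn3)[nH]c(=O)c12`: 18%
- compound 2, `COc1ccc(-c2cc3[nH]nc(N)c3c(=O)[nH]2)cc1`: 7%

Two compounds of the shared core have been run in an assay on isolated protein for inhibition of MAP kinase-activated protein kinase 5 (Homo sapiens), read by mobility shift assay, tested at 30 uM; on this read-out higher numbers stand for more inhibition at the one concentration tested (going by the name of the read-out) and lower numbers for less inhibition. Compound 1 gives 18%, and compound 2 gives 7%. Compound 2 thus stands lowest of the two numbers; the gap to compound 1 lies beyond the usual scatter of this read-out, so the inhibition of compound 2 in this assay is the lower of the pair on what is shown. Both values are low at the single concentration tested.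

Compound 3, `CN1CCN(c2ccc(-c3cc4[nH]nc(N)c4c(=O)[nH]3)cc2)CC1`, is not yet measured. It differs from compound 2 in one place: 4-methylpiperazin-1-yl in place of methoxy on an aromatic carbon. For the measured compounds named here, no step between measured compounds that differ in one place is available, so the effect of this change has no precedent.

Given the low reading of compound 2 in this assay, a step of only modest size is expected, most likely none beyond the scatter, with a slight lean upward. The expected step from compound 2 to compound 3 in this assay is a number 5 percentage points higher from compound 2 to compound 3 (within the scatter). Compound 3 is estimated at 12%, with a range from 0% to 32%.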

Compound 3, a percentage reported as inhibition, at one concentration (the size of the read-out at that concentration, not a potency): 11%
Compound 3: middle estimate off by 1 percentage points, on the high side; the measured number falls inside the stated range.
By their numbers in this assay, from the lowest: compounds 2, 3 and 1 (each within the scatter of the next, the first and the last beyond it).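

In this assay, 4-methylpiperazin-1-yl in place of methoxy on an aromatic carbon, para to a large group, gives a number 4 percentage points higher from compound 2 to compound 3 (within the scatter), the first one-place step available in the series. At this position, therefore, a six-membered non-aromatic ring with 2 hetero atoms can replace a small group with no ring, and the reading does not separate from that of compound 2, though both readings sit low and a single step at one concentration says little about how the position behaves more widely. No measurement shown here offers an explanation for this step or for the low readings of compound 2 and compound 3.

Still open, going by these compounds, is whether a smaller substituent such as fluorine, an amine, a carboxylic acid, or a longer chain ending in morpholine on this same aromatic carbon would give a reading beyond the scatter of compound 2 in this assay. For the compounds shown here, also open is whether any one-place change on the shared core can lift inhibition well clear of these low readings, since only this one step can be read so far.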